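An Amino Group Returns to the Carbonyl Carbon

The source may report more compounds than this note shows. Statements on the series, on what has been measured and on what is new or still open speak of the compounds shown alone.

In a functional assay on Shh Light II cells (Mus musculus) for inhibition, read by a luciferase reporter (on this read-out lower numbers stand for stronger inhibition and higher numbers for weaker inhibition), compound 1 `O=C(NC1CCC(O)CC1)N1CCC(c2nc(-c3ccc4ccccc4n3)no2)CC1` gives 2700 nM and compound 2 `O=C(Nc1ncccc1Cl)N1CCC(c2nc(-c3ccc4ccccc4n3)no2)CC1` gives 2800 nM; a 1.0-fold higher number from compound 1 to compound 2 (0.02 log units; within the scatter) keeps this pair within the scatter. Compound 3 `COc1ccccc1OC(=O)N1CCC(c2nc(-c3ccc4ccccc4n3)no2)CC1` has the lowest number of the three, at 250 nM. Both steps leading to it, an 11-fold lower number from compound 1 to compound 3 (1.03 log units; beyond the scatter) and an 11-fold lower number from compound 2 to compound 3 (1.05 log units; beyond the scatter), lie beyond the scatter, and each places 2-methoxyphenoxy on the carbonyl carbon in place of an amino group.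

Compound 4 `Cc1ccccc1NC(=O)N1CCC(c2nc(-c3ccc4ccccc4n3)no2)CC1` runs the opposite way, with (2-methylphenyl)amino in place of 2-methoxyphenoxy on a carbonyl carbon. The closest guide is compound 2, which carries (3-chloropyridin-2-yl)amino and shows an 11-fold lower number from compound 2 to compound 3 (1.05 log units; beyond the scatter). Going by the values given here, only two amino compounds have been measured, and neither holds the 2-methylphenyl group, so the loss may be only partial. A rise somewhat smaller than those two steps is therefore expected, estimated as a 3.6-fold higher number from compound 3 to compound 4 (0.56 log units; beyond the scatter). For compound 4 the estimated value is 900 nM, with an expected range of 250 nM to 3000 nM.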

Compound 4, half-maximal inhibitory concentration: 440 nM
Estimate against measurement, compound 4: 2.0-fold (0.31 log units) above; low and high end bracket the measured number.
By their numbers in this assay, from the lowest: compounds 3 and 4 (each within the scatter of the next); then compounds 1 and 2 (each within the scatter of the next).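

Compound 4 shows that an amino group on the carbonyl carbon does not by itself bring the higher numbers of compounds 1 and 2 in this assay: (2-methylphenyl)amino in place of 2-methoxyphenoxy gives only (a 1.8-fold higher number from compound 3 to compound 4 (0.25 log units; within the scatter)). What the nitrogen carries therefore counts among these ureas, with 2-methylphenyl in place of 3-chloropyridin-2-yl on the amide-type nitrogen giving (a 6.4-fold lower number from compound 2 to compound 4 (0.80 log units; beyond the scatter)) and 2-methylphenyl in place of 4-hydroxycyclohexyl giving (a 6.1-fold lower number from compound 1 to compound 4 (0.79 log units; beyond the scatter)). Nothing available here explains these differences.

The compounds shown leave open how much depends on the methyl group of compound 4, which plain phenylamino on the carbonyl carbon would address. They also leave open whether (2-methoxyphenyl)amino would match 2-methoxyphenoxy, the closest comparison for the linking atom alone.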